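The source may hold more compounds than are shown below. What is called first, only, known or untested is meant among the compounds shown, and "the series" means these compounds.

Compound 1 `Cc1cn(C2CCN(Cc3cccc(Oc4ccc(F)c(F)c4)c3)CC2)c(=O)[nH]c1=O` carries a 3,4-difluorophenyl group on an oxygen attached to an aromatic ring. In an ADME assay on MRC5 cells (Homo sapiens) for cytotoxicity, read by fluorescence and resazurin assay, with a stated time of 3 days (on this read-out higher numbers stand for weaker inhibition and lower numbers for stronger inhibition), compound 1 gives > 64000 nM, which is a limit of the assay rather than a number. Compound 2 `Cc1cn(C2CCN(Cc3ccnc(Oc4ccccc4)c3)CC2)c(=O)[nH]c1=O` and compound 3 `Cc1cn(C2CCN(Cc3cc(Oc4ccccc4)ccn3)CC2)c(=O)[nH]c1=O` share the same core. In this assay compound 2 gives > 64000 nM, again a limit. In this assay compound 3 gives > 64000 nM, also a limit. Among the measured compounds shown here, compound 1 therefore stands where every measured compound stands, at the limit of > 64000 nM in this assay, at which 3 of the 3 values shown sit, so no measured step separates any pair and nothing says whether one compound is stronger or weaker than another.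

Compound 4 `Cc1cn(C2CCN(Cc3cccc(OC4CCCCC4)c3)CC2)c(=O)[nH]c1=O` differs from compound 1 in one place: cyclohexyl in place of 3,4-difluorophenyl on an oxygen on an aromatic ring. For the measured compounds named here, none of the measured compounds reaches a number, so there is no measured step to lean on. The expectation for compound 4 is that the step that the limit leaves unreadable from compound 1 to compound 4 amounts to none beyond the scatter. Compound 4 is expected to give 80000 nM, within 30000 nM to 250000 nM, most likely reported again only as a limit.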

Compound 4, half-maximal inhibitory concentration: 23600 nM
Beside the measured number, compound 4's estimate is 3.4-fold (0.53 log units) above it, outside the stated range (below it).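

The group on this oxygen can move the read-out. In this assay, among the compounds shown here, cyclohexyl in place of 3,4-difluorophenyl gives an at least 2.7-fold lower number from compound 1 to compound 4 (0.43 log units; beyond the scatter), a step beyond the usual scatter and towards stronger inhibition, and compound 4 is the first compound here to reach a number rather than a limit. The full size of the step cannot be read because compound 1 gives only a limit, like most of the values shown: the limit of > 64000 nM in this assay, at which 3 of the 4 values shown sit.

This single change replaces an aromatic ring with a non-aromatic one and also removes both fluorines, and the compounds shown do not separate these two differences. They also leave open how a cyclopentyl ring, a longer chain or an amine on the same oxygen would read in this assay.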